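Methyl on the aromatic nitrogen of compound 2

The compounds below may be only part of what the source reports. "The series", "measured", "known", "first", "only" and "open" are said of these compounds alone.

For the measured compounds named here, in a functional assay on A549 cells (Homo sapiens) for antiproliferative activity, read by MTT assay, with a stated time of 48 h (a higher number here means a weaker inhibitor, a lower number a stronger inhibitor), compound 2 (`COc1cc(C(=O)/C=C/c2c[nH]c3ccccc23)cc([N+](=O)[O-])c1OC`) gives 1510 nM and holds the highest number of the three measured so far. Compound 1 (`COc1ccc2c(/C=C/C(=O)c3cc(OC)c(OC)c([N+](=O)[O-])c3)c[nH]c2c1`) gives 331 nM in this assay and compound 3 (`COc1ccc2c(/C=C(\C)C(=O)c3cc(OC)c(OC)c([Se]C)c3)c[nH]c2c1`) gives 8 nM in the same read-out, and both numbers lie lower than that of compound 2, beyond the scatter.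

Compound 4 (`COc1cc(C(=O)/C=C/c2cn(C)c3ccccc23)cc([N+](=O)[O-])c1OC`) is compound 2 with methyl in place of hydrogen on an aromatic nitrogen.

Going by the values given here, no measured step touches this nitrogen. Among the compounds with values here, the only step at a single place is a 4.6-fold higher number from compound 1 to compound 2 (0.66 log units; beyond the scatter) and it is hydrogen in place of methoxy on an aromatic carbon. That is a different place, so this modest step offers a scale for a one-place change and no direction for the new one.

With no direction available from the data, no step beyond the scatter is expected in this assay as the central case. The estimated change is a 1.3-fold lower number from compound 2 to compound 4 (0.10 log units; within the scatter) and a step of the modest size seen above remains possible either way. For compound 4 the estimate is 1200 nM within a range from 330 nM to 5000 nM as the expected span.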

Compound 4, half-maximal inhibitory concentration: 1060 nM
The estimate for compound 4 lay 1.1-fold (0.05 log units) above the measured number; low and high end bracket the measured number.
By their numbers in this assay, from the lowest: compound 3; then compound 1; then compounds 4 and 2 (each within the scatter of the next).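

In this assay, methyl in place of hydrogen on the aromatic nitrogen gives a 1.4-fold lower number from compound 2 to compound 4 (0.15 log units; within the scatter) and so stays within the scatter: on the core of compound 2, the hydrogen at this nitrogen can be exchanged for methyl with no readable change. For the compounds shown here, this is the first reading at this position, as the earlier single-place step, a 4.6-fold higher number from compound 1 to compound 2 (0.66 log units; beyond the scatter) with hydrogen in place of methoxy on an aromatic carbon, lies at a different place and beyond the scatter. No available evidence bears on this result, so the reading stands as an observation on this one pair.

Still open, going by these compounds, is whether a larger group on this nitrogen, such as benzyl, acetyl or a longer chain ending in an amine, would also leave the number within the scatter of that of compound 2. On these data alone, it is also open whether methyl at this nitrogen would read the same on the core of compound 1, which carries the methoxy group, or on the core of compound 3, where the number is far lower.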